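A few compounds are considered here, and "the series" means these few. Any claim that something is new, unique, unknown or untested is made for them only; others in the source may bear on it.

Measured so far in a functional assay on PANC-1 cells (Homo sapiens) for antiproliferative activity, read by MTT assay, with a stated time of 48 h; a lower number here means a stronger inhibitor, a higher number a weaker inhibitor:
- compound 1 `COc1ccc(-c2c(Nc3ccc(C)cc3)c3ccccc3oc2=O)cc1`: 66100 nM
- compound 2 `COc1ccc(-c2c(Nc3cccc(C(F)(F)F)c3)c3ccccc3oc2=O)cc1`: 49100 nM

Within the data shown here, only two numbers exist, and compound 1 cannot be separated from compound 2. Compound 3 `COc1ccc(-c2c(Nc3ccc(C)cc3)c3ccc(OC)cc3oc2=O)cc1` keeps compound 1 except for one change: methoxy in place of hydrogen on an aromatic carbon. Among the measured compounds shown here, the only measured step, a 1.3-fold lower number from compound 1 to compound 2 (0.13 log units; within the scatter), changes the group on the nitrogen instead, so it is only an indirect guide. No step beyond the scatter is therefore expected in this assay. The estimated step is a 1.3-fold lower number from compound 1 to compound 3 (0.12 log units; within the scatter). Compound 3 is expected near 50000 nM, within an estimated range of 20000 nM to 120000 nM.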

Compound 3, half-maximal inhibitory concentration: 76500 nM
The estimate for compound 3 lay 1.5-fold (0.18 log units) below the measured number; low and high end bracket the measured number.
By their numbers in this assay, from the lowest: compounds 2, 1 and 3 (each within the scatter of the next).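

In this assay, methoxy in place of hydrogen gives a 1.2-fold higher number from compound 1 to compound 3 (0.06 log units; within the scatter), a change on an aromatic carbon of the fused system of two rings, whereas the earlier step changed the group on the nitrogen. Compound 3 therefore cannot be separated from compound 1, so at this position methoxy leaves no readable mark on the number. No measurement at hand offers an explanation for this result.

Going by these compounds, whether an amine, a carboxylic acid or a longer chain at this same position would give a step beyond the scatter remains open. So does whether methoxy would give the same result with the 3-(trifluoromethyl)phenyl group of compound 2 on the nitrogen.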